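Pyrrolidine in Place of Methoxypiperidine: Expected Solubility

The source may hold more compounds than are shown below. What is called first, only, known or untested is meant among the compounds shown, and "the series" means these compounds.

Three measured compounds share one core and differ only in the ring carried on a saturated chain carbon bound to a saturated ring carbon. In a physicochemical assay for solubility, read by spectrophotometry, in phosphate buffer, with a stated time of 2 h, at pH 7.4 (a higher number here means a more soluble compound, a lower number a less soluble compound), compound 1 `COc1ccc2[nH]c(C(=O)N3CC(=O)N(Cc4ccccc4)[C@@H](CN4CCC5(CC4)CC5)C3)cc2c1` gives 28200 nM. Compound 2 `COc1ccc2[nH]c(C(=O)N3CC(=O)N(Cc4ccccc4)[C@@H](CN4CCC(C)CC4)C3)cc2c1` gives 93100 nM in this assay, and a 3.3-fold higher number from compound 1 to compound 2 (0.52 log units; beyond the scatter). Compound 3 `COc1ccc2[nH]c(C(=O)N3CC(=O)N(Cc4ccccc4)[C@@H](CN4CCC(OC)CC4)C3)cc2c1` reaches only a limit in this assay, recorded as > 25000 nM, so its true number is not known. With compound 3 sitting at the limit of > 25000 nM in this assay, at which 1 of the 3 values shown sits, a step that the limit leaves unreadable from compound 1 to compound 3 and a step that the limit leaves unreadable from compound 2 to compound 3.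

Compound 4 `COc1ccc2[nH]c(C(=O)N3CC(=O)N(Cc4ccccc4)[C@@H](CN4CCCC4)C3)cc2c1` is the unmeasured partner: pyrrolidin-1-yl in place of 4-methoxypiperidin-1-yl on a saturated chain carbon bound to a saturated ring carbon. For the measured compounds named here, no measured step involves the pyrrolidine, and the one step that could be read, between a spiro-fused piperidine and a methylpiperidine, was modest in size. The change to compound 4 is therefore expected to move this assay by little beyond the scatter, most likely upward from the limit. Compound 4 is expected to give about 60000 nM in this assay, within 20000 nM to 160000 nM. That estimate means a step that the limit leaves unreadable from compound 3 to compound 4.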

Compound 4, solubility: > 25000 nM
Compound 4: only a limit was reported (the forecaster's own chance of this, stated with the estimate: 30%); the middle value does not contradict the limit.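

In this assay compound 4 gives > 25000 nM, which is a limit and not a number. For the compounds shown here, no step from compound 1, compound 2 or compound 3 to compound 4 can be read, and the limit is shared: the limit of > 25000 nM in this assay, at which 2 of the 4 values shown sit. Going by these compounds, the true numbers for compound 3 and compound 4 remain open, and so does how pyrrolidin-1-yl compares with the piperidine groups.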